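The source may report more compounds than this note shows. Statements on the series, on what has been measured and on what is new or still open speak of the compounds shown alone.

Working notes on the series. All compounds share the core shown for compound 1 `O=C(CCc1ccccc1)Nc1nnc(-c2ccc3c(c2)OCCO3)s1`; they differ only in the group on the carbonyl carbon of the amide. In a functional assay on HepG2 cells (Homo sapiens) for antiproliferative activity, read by MTT assay, with a stated time of 48 h (a lower number here means that less compound is needed, a higher number that more compound is needed for the effect), compound 1 gives 15.3 ug/mL. Compound 2 `Nc1ccc(C(=O)Nc2nnc(-c3ccc4c(c3)OCCO4)s2)cc1` carries 4-aminophenyl in place of phenethyl. In this assay compound 2 reaches only > 100 ug/mL, which is a limit of the assay and not a number. Compound 3 `O=C(Nc1nnc(-c2ccc3c(c2)OCCO3)s1)c1ccccn1` carries pyridin-2-yl on the carbonyl carbon. In this assay compound 3 likewise stops at > 100 ug/mL, again a limit rather than a number. Among the measured compounds shown here, compound 3 thus stands at the limit of > 100 ug/mL in this assay, at which 2 of the 3 values shown sit; the step of an at least 6.5-fold higher number from compound 1 to compound 3 (0.81 log units; beyond the scatter) is the one readable step leading to it, while the step that the two limits leave unreadable from compound 2 to compound 3 cannot be sized. Compound 4 `O=C(Nc1nnc(-c2ccc3c(c2)OCCO3)s1)c1ccncc1` differs from compound 3 by pyridin-4-yl in place of pyridin-2-yl on a carbonyl carbon. For the measured compounds named here, no measured step compares two pyridyl groups with each other; the steps that bear on the question, an at least 6.5-fold higher number from compound 1 to compound 2 (0.81 log units; beyond the scatter) and an at least 6.5-fold higher number from compound 1 to compound 3 (0.81 log units; beyond the scatter), show only that both aryl amides tested so far sit at the limit where compound 1 does not. The expected step that the limit leaves unreadable from compound 3 to compound 4 is therefore none beyond the scatter. Compound 4 is estimated at 130 ug/mL, within a range from 40 ug/mL to 400 ug/mL, and most probably this assay will again return only a limit for compound 4.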

Compound 4, half-maximal effective concentration: > 100 ug/mL
Compound 4: a limit, no number; the forecaster's own chance of this, stated with the estimate: 75%; the middle value does not contradict the limit.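

In this assay compound 4 stops at > 100 ug/mL, which is a limit and not a number. The change from phenethyl to pyridin-4-yl gives an at least 6.5-fold higher number from compound 1 to compound 4 (0.81 log units; beyond the scatter), so a second pyridyl attachment now shares the reading of pyridin-2-yl and 4-aminophenyl on this carbonyl carbon, and joining the same atoms differently in the pyridyl group brings no measurable value into view: the limit of > 100 ug/mL in this assay, at which 3 of the 4 values shown sit. Among the compounds shown, only compound 1, with phenethyl, gives a number, and the steps among compound 2, compound 3 and compound 4 cannot be read, as both ends of each are limits.

Open, going by these compounds, is whether a plain phenyl, a benzyl or a longer chain such as 3-phenylpropyl on the carbonyl carbon would give a number, and so whether the reading of compound 1 depends on the chain in phenethyl or on its phenyl ring. Also open, on these data alone, are how far compound 2, compound 3 and compound 4 lie from one another beyond the limit and whether a pyridin-3-yl group would join them there.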